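The source may report more compounds than this note shows. Statements on the series, on what has been measured and on what is new or still open speak of the compounds shown alone.

Measured compounds:
compound 1 `Oc1cccc(-c2cc(-c3ccc(Cl)cc3)nc(-c3ccsc3)c2)c1`: 11500 nM
compound 2 `Oc1cccc(-c2cc(-c3ccccc3)nc(-c3ccc(Cl)cc3)c2)c1`: 11300 nM

In a functional assay on T47D cells (Homo sapiens) for cytotoxicity, read by CCK-8 assay and cell counting, with a stated time of 2 days (on this read-out lower numbers stand for stronger inhibition and higher numbers for weaker inhibition), compound 1 gives 11500 nM and compound 2 gives 11300 nM. Among the measured compounds shown here, the one step between them, a 1.0-fold lower number from compound 1 to compound 2 (0.01 log units; within the scatter), is within the scatter, so the two numbers cannot be told apart; compound 2 holds the lower of the two figures only by a margin inside the scatter, with compound 1 as its nearest neighbour.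

Compound 3 `Oc1cccc(-c2cc(-c3ccc(Cl)cc3)nc(-c3ccco3)c2)c1` is not yet measured. It differs from compound 2 by furan-2-yl in place of phenyl on an aromatic carbon. For the measured compounds named here, the only measured step that touches this position is the exchange of thiophen-3-yl for phenyl, a 1.0-fold lower number from compound 1 to compound 2 (0.01 log units; within the scatter), which left the read-out unchanged within the scatter. Thiophen-3-yl and phenyl gave the same number there, so furan-2-yl is expected to give no step beyond the scatter either. For compound 3 the expected step is a 1.1-fold higher number from compound 2 to compound 3 (0.03 log units; within the scatter). Compound 3 is therefore estimated at 12000 nM, with a range from 5000 nM to 30000 nM.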

Compound 3, half-maximal inhibitory concentration: 10500 nM
The estimate for compound 3 lay 1.1-fold (0.06 log units) above the measured number; the range from low to high includes it.
By their numbers in this assay, from the lowest: compounds 3, 2 and 1 (each within the scatter of the next).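

In this assay the exchange of phenyl for furan-2-yl gives a 1.1-fold lower number from compound 2 to compound 3 (0.03 log units; within the scatter) and the exchange of thiophen-3-yl for furan-2-yl gives a 1.1-fold lower number from compound 1 to compound 3 (0.04 log units; within the scatter), so the three aromatic groups on this carbon next to the ring nitrogen cannot be told apart. The series now shows that a five-membered aromatic ring with an oxygen, which brings a hydrogen-bond acceptor that phenyl lacks, gives no step beyond the scatter at this position. No supporting data bear on the reason for this flat result.

On these data alone, whether any group at this position can move the number beyond the scatter stays open, for instance an amine, a carboxylic acid or a longer alkyl chain in place of the aromatic ring. As far as these compounds go, the contribution of the 3-hydroxyphenyl and 4-chlorophenyl groups also stays open, since both are common to all three compounds.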